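The compounds below may be only part of what the source reports. "The series", "measured", "known", "first", "only" and "open" are said of these compounds alone.

Compound 1 `COc1ccc(CN(C(=O)CSc2nc3ccccc3s2)c2cc(OC)c(OC)c(OC)c2)cc1[N+](=O)[O-]` is one of three amides built on a shared core, alongside compound 2 `COc1ccc2nc(SCC(=O)N(Cc3ccc(OC)c(O)c3)c3cc(OC)c(OC)c(OC)c3)sc2c1` and compound 3 `COc1ccc(CN(C(=O)CSc2nc3cc(Br)ccc3s2)c2cc(OC)c(OC)c(OC)c2)cc1O`. In a functional assay on MGC-803 cells (Homo sapiens) for antiproliferative activity, read by MTT assay, with a stated time of 48 h (a higher number here means a weaker inhibitor, a lower number a stronger inhibitor), compound 1 gives 682 nM, the highest of the three numbers, though against compound 3 the gap lies within the scatter; compound 3 gives 372 nM, and compound 2 gives 71 nM. Among the measured compounds shown here, the only measured step, a 5.2-fold higher number from compound 2 to compound 3 (0.72 log units; beyond the scatter), alters the group on the sulfur and so does not touch the part changed here. Compound 4 `COc1cc(N(Cc2ccc(Br)cc2)C(=O)CSc2nc3ccccc3s2)cc(OC)c1OC` differs from compound 1 by 4-bromophenyl in place of 4-methoxy-3-nitrophenyl on a saturated chain carbon bound to an amide-type nitrogen. For the measured compounds named here, no measured step covers this change, so no shift beyond the scatter is expected, and compound 4 is estimated at a 1.4-fold lower number from compound 1 to compound 4 (0.13 log units; within the scatter). Compound 4 is therefore expected to give about 500 nM, between 150 nM and 1600 nM.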

Compound 4, half-maximal inhibitory concentration: 48100 nM
Compound 4: middle estimate off by 96-fold (1.98 log units), on the low side, and the stated range ends below it.
By their numbers in this assay, from the lowest: compound 2; then compounds 3 and 1 (each within the scatter of the next); then compound 4.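

In this assay, the aromatic group on a saturated chain carbon bound to an amide-type nitrogen proves far from neutral: 4-bromophenyl in place of 4-methoxy-3-nitrophenyl gives a 71-fold higher number from compound 1 to compound 4 (1.85 log units; beyond the scatter) for this swap. Among the compounds shown here, the earlier step changed only the group on the sulfur, so this is the first sign that activity depends strongly on this second site. Nothing measured here accounts for the drop.

As far as these compounds go, because the swap removes methoxy and nitro and adds bromine together, the contribution of each stays open. A 4-aminophenyl or 4-carboxyphenyl group at this place would help to separate them.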